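Methylpiperazine amide to diisopropyl amide: expected cytotoxicity

The source may report more compounds than this note shows. Statements on the series, on what has been measured and on what is new or still open speak of the compounds shown alone.

Compound 1, `CS(=O)(=O)c1ccc(C(=O)N2CCC(C(=O)N3CCc4ccccc43)CC2)cc1[N+](=O)[O-]`, gives > 27000 nM in an ADME assay on HepG2 cells (Homo sapiens) for cytotoxicity, read by CellTiter-Glo and ATP content, with a stated time of 72 h (on this read-out lower numbers stand for an effect already at smaller amounts and higher numbers for an effect only at larger amounts of compound), a limit of the assay.
Compound 2, `CN(Cc1ccccc1)C(=O)C1CCN(C(=O)c2ccc(S(C)(=O)=O)c([N+](=O)[O-])c2)CC1`, gives > 27000 nM in this assay, again a limit.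
Compound 3, `CN1CCN(C(=O)C2CCN(C(=O)c3ccc(S(C)(=O)=O)c([N+](=O)[O-])c3)CC2)CC1`, gives > 27000 nM in this assay, also a limit.

Compound 3 thus stands where every measured compound stands: at the limit of > 27000 nM in this assay, at which 3 of the 3 values shown sit. The steps a step that the two limits leave unreadable from compound 1 to compound 2, a step that the two limits leave unreadable from compound 1 to compound 3 and a step that the two limits leave unreadable from compound 2 to compound 3 cannot be sized, since both ends of each sit at the limit.

Compound 4, `CC(C)N(C(=O)C1CCN(C(=O)c2ccc(S(C)(=O)=O)c([N+](=O)[O-])c2)CC1)C(C)C`, differs from compound 3 by diisopropylamino in place of 4-methylpiperazin-1-yl on a carbonyl carbon. No measured step sizes this change; the three amide replacements already seen, which span a ring amine, an open-chain benzylic amine and a basic ring, left the read-out at the limit each time. Compound 4 is therefore expected to behave alike, and the step that the limit leaves unreadable from compound 3 to compound 4 is expected to be none beyond the scatter, most likely again ending at the limit. The estimate for compound 4 in this assay is 40000 nM, with a range from 20000 nM to 100000 nM.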

Compound 4, half-maximal effective concentration: > 27000 nM
Compound 4 gave a limit, no number; the forecaster's own chance of this, stated with the estimate: 85%; the middle value lies beyond the limit too.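

Compound 4 sits at a limit of this assay, as do compound 1, compound 2 and compound 3, so none of its steps to them can be read: the limit of > 27000 nM in this assay, at which 4 of the 4 values shown sit.

The compounds shown leave open how far apart these four really lie, and whether any change at this carbonyl carbon would bring a value within the assay's range.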